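A few compounds are considered here, and "the series" means these few. Any claim that something is new, unique, unknown or untested is made for them only; others in the source may bear on it.

Of the compounds shown here, two have been measured so far in a functional assay on a cell-free system (Platelet, plasma, Homo sapiens) for inhibition; on this read-out higher numbers stand for weaker inhibition and lower numbers for stronger inhibition. Compound 1 (`O=C(Nc1ccc(OCc2ccc(F)cc2)cc1)C1CCNCC1`) gives 93000 nM, and compound 2 (`O=C(Nc1cccc(OCc2ccc(-c3ccc(F)cc3)cc2)c1)C1CCNCC1`) gives 19000 nM. Compound 2 therefore holds the lower of the two numbers, meaning the stronger inhibition of the pair, and the gap between them lies beyond the usual scatter. The two structures differ in more than one place, so this gap cannot be tied to any single change.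

Compound 3 (`O=C(Nc1cccc(OCc2ccc(-c3cc(F)cc(F)c3)cc2)c1)C1CCNCC1`) has not yet been measured. It departs from compound 2 at one place, with 3,5-difluorophenyl in place of 4-fluorophenyl on an aromatic carbon, para to a large group: 3,5-difluorophenyl in place of 4-fluorophenyl on an aromatic carbon.

Among the measured compounds shown here, no measured pair shows a change of this kind. The expectation therefore rests only on compound 2 at 19000 nM and on the structural change itself. Only a small move is expected in this assay, most likely none beyond the scatter, with no firm direction. The estimated step is a 1.2-fold lower number from compound 2 to compound 3 (0.07 log units; within the scatter). Compound 3 is expected at 16000 nM, with an estimated range of 6000 nM to 42000 nM.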

Compound 3, half-maximal inhibitory concentration: 17000 nM
Compound 3: the middle estimate sits 1.1-fold (0.03 log units) below what was measured; the range from low to high includes it.
By their numbers in this assay, from the lowest: compounds 3 and 2 (each within the scatter of the next); then compound 1.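

In this assay, placing 3,5-difluorophenyl in place of 4-fluorophenyl on an aromatic carbon, para to a large group, gives a 1.1-fold lower number from compound 2 to compound 3 (0.05 log units; within the scatter) and leaves compound 2 and compound 3 indistinguishable on this read-out. Among the compounds shown here, this is the first comparison that differs in only one place, and it shows that, for this one pair, the fluorine pattern on this phenyl group can be altered with no effect that rises beyond the scatter. Nothing measured here bears on why the two compounds read alike.

As far as these compounds go, it remains open whether a different kind of group at this place, such as an amine, a carboxylic acid or a methoxy group, would give a step beyond the scatter, or whether this position stays as tolerant when the substituents are no longer fluorine. Also open is which of the structural differences between compound 1 and compound 2 accounts for the gap between them, since a comparison in one place is available only for the fluorine pattern.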